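A few compounds are considered here, and "the series" means these few. Any claim that something is new, unique, unknown or untested is made for them only; others in the source may bear on it.

Compound 1 `COc1cccc2c1c(C(=O)/C=C(\O)C(=O)O)cn2Cc1cc(F)ccc1F`: 46200 nM
Compound 2 `COc1cccc2c1c(C(=O)/C=C(\O)C(=O)O)cn2Cc1ccccc1F`: 70500 nM
Compound 3 `COc1cccc2c1c(C(=O)/C=C(\O)C(=O)O)cn2Cc1ccc(F)cc1F`: 20800 nM

These three numbers come from an ADME assay on MT4 cells (Homo sapiens) for cytotoxicity, read by MTT assay; on this read-out lower numbers stand for higher toxicity in this test and higher numbers for lower toxicity in this test. Compound 3 gives the lowest number of the three: a 2.2-fold lower number from compound 1 to compound 3 (0.35 log units; beyond the scatter) and a 3.4-fold lower number from compound 2 to compound 3 (0.53 log units; beyond the scatter). Compound 4 `COc1cccc2c1c(C(=O)/C=C(\O)C(=O)O)cn2Cc1cccc(F)c1` differs from it by 3-fluorophenyl in place of 2,4-difluorophenyl on a saturated chain carbon bound to an aromatic nitrogen. Within the data shown here, no measured pair makes exactly this swap. The nearest guides are a 1.5-fold higher number from compound 1 to compound 2 (0.18 log units; within the scatter) and a 3.4-fold lower number from compound 2 to compound 3 (0.53 log units; beyond the scatter): taking one fluorine away has left the number little changed or raised it. Since compound 4 carries a single fluorine on that ring, it is expected to move back toward the higher numbers, an estimated step of a 2.2-fold higher number from compound 3 to compound 4 (0.34 log units; beyond the scatter). The estimate for compound 4 is 45000 nM, with a range from 18000 nM to 110000 nM.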

Compound 4, half-maximal cytotoxic concentration: 65800 nM
Compound 4: the middle estimate sits 1.5-fold (0.17 log units) below what was measured, within the range that was stated.
By their numbers in this assay, from the lowest: compound 3; then compounds 1, 4 and 2 (each within the scatter of the next).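

In this assay, the 3-fluorobenzyl group of compound 4 falls with the other compounds rather than with compound 3: a 3.2-fold higher number from compound 3 to compound 4 (0.50 log units; beyond the scatter), while a 1.1-fold lower number from compound 2 to compound 4 (0.03 log units; within the scatter) and a 1.4-fold higher number from compound 1 to compound 4 (0.15 log units; within the scatter). Among these four, only the 2,4-difluorobenzyl group of compound 3 stands apart, and moving the single fluorine from the 2-fluorophenyl of compound 2 to the 3-fluorophenyl of compound 4 leaves no readable change. Adding one fluorine does not clearly give different results in the two cases: the same change on two cores in this assay, a 3.4-fold lower number (0.53 log units; beyond the scatter) from compound 2 to compound 3 and a 1.4-fold lower number (0.15 log units; within the scatter) from compound 4 to compound 1, 2.4-fold (0.38 log units) apart, within the scatter of two such steps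

Still open, as far as these compounds go, is whether a plain benzyl or a 2,4-dichlorobenzyl group at this position would give a number as low as compound 3.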